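Swapping Benzylamino for Heptyl at the Carbonyl

The source may hold more compounds than are shown below. What is called first, only, known or untested is meant among the compounds shown, and "the series" means these compounds.

Measured so far:
compound 1 `CN(CCCc1ccccc1)Cc1cn(CC(O)COC(=O)NCc2ccccc2)nn1`, 79%
compound 2 `CN(Cc1cn(CC(O)COC(=O)NCc2ccccc2)nn1)CC1CCCCC1`, 32%

In an assay on nucleic acid for inhibition of Nucleic Acid, read by fluorescence, tested at 100 uM (a lower number here means less inhibition, a higher number more inhibition at the concentration tested (going by the name of the read-out)), compound 1 gives 79%, the highest of the two numbers. Its nearest neighbour is compound 2, which in this assay gives 32%; the step is a number 47 percentage points lower from compound 1 to compound 2 (beyond the scatter), with cyclohexyl in place of phenethyl on a saturated chain carbon bound to an amine nitrogen.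

Compound 3 `CCCCCCCC(=O)OCC(O)Cn1cc(CN(C)CCCc2ccccc2)nn1` has not yet been measured. It differs from compound 1 by heptyl in place of benzylamino on a carbonyl carbon, the carbamate becoming an ester; cut one bond further out, this reads benzylcarbamoyl to heptylcarbonyl. Among the compounds with values here, no measured step touches this carbonyl carbon. Within the data shown here, the single known step concerns another place and was large, so it shows only that this series can respond strongly to a change, not in which direction this one goes. The step from compound 1 to compound 3 is therefore expected to be a number 24 percentage points lower from compound 1 to compound 3 (beyond the scatter), with wide uncertainty. Compound 3 is expected to give 55% in this assay, between 20% and 85%.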

Compound 3, a percentage reported as inhibition, at one concentration (the size of the read-out at that concentration, not a potency): 12%
Compound 3: middle estimate off by 43 percentage points, on the high side, outside the stated range (below it).
By their numbers in this assay, from the lowest: compound 3; then compound 2; then compound 1.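

Within the data shown here, the carbonyl carbon, which no earlier step touched, turns out to be a place to which this assay responds strongly: heptyl in place of benzylamino gives a number 67 percentage points lower from compound 1 to compound 3 (beyond the scatter). The change removes the six-membered aromatic ring and the hydrogen-bond donor of benzylamino together, and turns the carbamate into an ester, so this single step cannot show which of these differences matters. Nothing available here bears on why the number falls, and the drop remains without an assigned cause.

As far as these compounds go, what stays open is whether the ring, the nitrogen with its hydrogen or the chain itself decides the outcome at this carbonyl carbon. A heptylamino group there would keep the carbamate while carrying the heptyl chain, and a phenylpropyl group would keep the ring on an ester, so each would pull these differences apart.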